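Moving the hydroxy group on the sulfonyl piperidine

The compounds below may be only part of what the source reports. "The series", "measured", "known", "first", "only" and "open" are said of these compounds alone.

Values in a functional assay on A2780 cells (Homo sapiens) for cytotoxicity, read by sulforhodamine B assay, with a stated time of 72 h (a higher number here means a weaker inhibitor, a lower number a stronger inhibitor), for the measured compounds
- compound 1 `O=C(NCc1ccc(S(=O)(=O)C2CCOCC2)cc1)N1Cc2ccncc2C1` at 35 nM
- compound 2 `CN1CCC(S(=O)(=O)c2ccc(CNC(=O)N3Cc4ccncc4C3)cc2)CC1` at 99 nM
- compound 3 `O=C(NCc1ccc(S(=O)(=O)N2CCC(O)CC2)cc1)N1Cc2ccncc2C1` at 98 nM

Compound 3 holds the second highest of the three numbers. It is level with compound 2 within the scatter, as a 1.0-fold lower number from compound 2 to compound 3 (0.00 log units; within the scatter) shows, and its number lies clearly above that of compound 1, as a 2.8-fold higher number from compound 1 to compound 3 (0.45 log units; beyond the scatter) shows.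

For the measured compounds named here, the next compound is compound 4 `O=C(NCc1ccc(S(=O)(=O)N2CCC[C@@H](O)C2)cc1)N1Cc2ccncc2C1` with 3-hydroxypiperidin-1-yl in place of 4-hydroxypiperidin-1-yl on a sulfonyl sulfur and no measured compound yet carries this group. The nearest evidence comes from the other changes on the sulfonyl sulfur. Leaving oxan-4-yl gave modest steps of a 2.8-fold higher number from compound 1 to compound 2 (0.45 log units; beyond the scatter) and a 2.8-fold higher number from compound 1 to compound 3 (0.45 log units; beyond the scatter) while exchanging the two piperidine groups gave a 1.0-fold lower number from compound 2 to compound 3 (0.00 log units; within the scatter) with no change beyond the scatter. None of these steps relocates the hydroxy group, so they guide the expectation only loosely.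

The expected change is a 1.0-fold higher number from compound 3 to compound 4 (0.01 log units; within the scatter) in this assay and no step beyond the scatter is anticipated in either direction. For compound 4 the estimated value is 100 nM with an expected range from 40 nM to 250 nM as the working figure.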

Compound 4, half-maximal inhibitory concentration: 70 nM
Beside the measured number, compound 4's estimate is 1.4-fold (0.15 log units) above it, within the range that was stated.
By their numbers in this assay, from the lowest: compounds 1, 4, 3 and 2 (each within the scatter of the next, the first and the last beyond it).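

In (this assay), moving the hydroxy group from 4-hydroxypiperidin-1-yl to 3-hydroxypiperidin-1-yl on the sulfonyl sulfur, with the same atoms joined differently, gives a step within the scatter (a 1.4-fold lower number from compound 3 to compound 4 (0.15 log units; within the scatter)), so these two hydroxy placements on the piperidine cannot be told apart here. Compound 4 also lies within the scatter of the two other neighbours (a 1.4-fold lower number from compound 2 to compound 4 (0.15 log units; within the scatter)) and (a 2.0-fold higher number from compound 1 to compound 4 (0.30 log units; within the scatter)), whereas the step to compound 3 from the oxan-4-yl compound is printed beyond it (a 2.8-fold higher number from compound 1 to compound 3 (0.45 log units; beyond the scatter)), but the small gap between the two hydroxy isomers does not support treating them as different. No supporting measurement is available to explain this outcome.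

From the compounds shown here alone, compound 4 carries one defined stereocentre, so it remains open whether the opposite configuration of 3-hydroxypiperidin-1-yl would give a number in the same range. Going by these compounds, it also remains open whether an amine such as 3-aminopiperidin-1-yl, or a carboxylic acid on the piperidine, would keep the number close to those of the hydroxy compounds on the sulfonyl sulfur.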